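A Fluoro Step Repeated on a Second Core

A few compounds are considered here, and "the series" means these few. Any claim that something is new, unique, unknown or untested is made for them only; others in the source may bear on it.

The measured compounds:
compound 1, `CCN(CC)CCCNc1nc(-c2ccc(NC(=O)Nc3ccccc3)cc2)nc2c(Cl)c(Cl)sc12`, gives 1780 nM in a functional assay on MDA-MB-231 cells (Homo sapiens) for cytotoxicity, read by MTT assay, with a stated time of 72 h; a higher number here means a weaker inhibitor, a lower number a stronger inhibitor
compound 2, `CCN(CC)CCCNc1nc(-c2ccc(NC(=O)Nc3ccccc3)cc2)nc2ccsc12`, gives 1230 nM in this assay
compound 3, `CCN(CC)CCCNc1nc(-c2ccc(NC(=O)Nc3ccc(F)cc3)cc2)nc2c(Cl)c(Cl)sc12`, gives 1630 nM in this assay

Compounds 1 and 3 share one core, compound 2 has another; the difference between the two cores is not broken down here. All three values lie within the scatter of each other, so no order among them can be read. From compound 1 to compound 3 the change is fluoro in place of hydrogen on an aromatic carbon, and it gave a 1.1-fold lower number from compound 1 to compound 3 (0.04 log units; within the scatter).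

Compound 4, `CCN(CC)CCCNc1nc(-c2ccc(NC(=O)Nc3ccc(F)cc3)cc2)nc2ccsc12`, has not yet been measured in this assay. It differs from compound 2 by fluoro in place of hydrogen on an aromatic carbon, the same change at the same place as that from compound 1 to compound 3, now applied to the core of compound 2.

The step from compound 2 to compound 4 in this assay is expected to be a 1.1-fold lower number from compound 2 to compound 4 (0.03 log units; within the scatter), resting on the earlier step of a 1.1-fold lower number from compound 1 to compound 3 (0.04 log units; within the scatter), which stayed within the scatter. Compound 4 is therefore expected to give about 1150 nM, most likely between 600 nM and 2300 nM.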

Compound 4, half-maximal inhibitory concentration: 530 nM
Compound 4: middle estimate off by 2.2-fold (0.34 log units), on the high side, outside the stated range (below it).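

In this assay, fluoro in place of hydrogen on the core of compound 2 gave a 2.3-fold lower number from compound 2 to compound 4 (0.37 log units; beyond the scatter), a modest step. Set beside the same change on the core of compound 1, this step cannot be told apart from the earlier one: the same change on two cores in this assay, a 1.1-fold lower number (0.04 log units; within the scatter) from compound 1 to compound 3 and a 2.3-fold lower number (0.37 log units; beyond the scatter) from compound 2 to compound 4, 2.1-fold (0.33 log units) apart, within the scatter of two such steps. Going by these compounds alone, the account therefore shows a change that, on the core of compound 2, goes with a lower number and that has no measurable dependence on the core in these two pairs, but it does not show that the core alters the size of the step, nor that the step carries over unchanged, as each core offers only a single pair and the earlier step on its own stays within the scatter.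

The compounds shown leave open whether chloro or methoxy, set in the place of fluoro, would behave alike on the two cores. They also leave open whether the same holds with a cyclic amine such as piperidine in place of the diethylamino group at the end of the chain.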